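Swapping the Aryl Group on the Sulfonyl of a Diamine

A few compounds are considered here, and "the series" means these few. Any claim that something is new, unique, unknown or untested is made for them only; others in the source may bear on it.

Compound 1 `Cc1ccc(C)c(S(=O)(=O)NCCCCCCNCc2ccc(Br)cc2)c1` gives 12000 nM in a functional assay on MIA PaCa-2 cells (Homo sapiens) for inhibition, read by MTT assay, with a stated time of 72 h; on this read-out higher numbers stand for weaker inhibition of growth and lower numbers for stronger inhibition of growth.
Compound 2 `O=S(=O)(NCCCNCc1cccc(Cl)c1)c1cc(C(F)(F)F)cc(C(F)(F)F)c1` gives 4400 nM in this assay.

Both compounds share a sulfonamide joined through a chain to an amine carrying a halogenated benzyl group. Of the two numbers, compound 1 has the highest, so it is the weaker grower-inhibitor here; compound 2 sits at a lower number, and that gap is beyond the scatter. Compound 3 `O=[N+]([O-])c1ccc(S(=O)(=O)NCCCCCCNCc2ccc(Br)cc2)cc1` keeps everything in compound 1 except the aryl group on the sulfonyl sulfur: 4-nitrophenyl in place of 2,5-dimethylphenyl on a sulfonyl sulfur. Among the compounds with values here, no measured pair isolates such a swap, so the size of the step is uncertain. Compound 3 is therefore expected to give about 8000 nM, within 2500 nM to 25000 nM. The expected step of a 1.5-fold lower number from compound 1 to compound 3 (0.18 log units; within the scatter) is a modest move toward a lower number, close to the edge of the scatter.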

Compound 3, concentration for 50% growth inhibition: 9800 nM
For compound 3 the middle estimate is 1.2-fold (0.09 log units) below the measured one; the range from low to high includes it.
By their numbers in this assay, from the lowest: compound 2; then compounds 3 and 1 (each within the scatter of the next).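

Within the data shown here, putting 4-nitrophenyl in place of 2,5-dimethylphenyl on the sulfonyl sulfur gives a 1.2-fold lower number from compound 1 to compound 3 (0.09 log units; within the scatter) in this assay, the first direct look at this position. On this read-out, the two aryl groups cannot be told apart, even though the entering group has 2 hydrogen-bond acceptors and the leaving group has 0. Nothing measured here explains why the two compounds read alike.

As far as these compounds go, it remains open how an amine or a carboxylic acid in place of the nitro group would read on the same phenyl ring. It is also unknown whether this aryl swap would read the same way on a shorter chain, as compound 2 differs from compound 1 in more than one place.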